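From sulfonyl to sulfanyl at compound 4

A few compounds are considered here, and "the series" means these few. Any claim that something is new, unique, unknown or untested is made for them only; others in the source may bear on it.

Values measured in a functional assay on DU-145 cells (Homo sapiens) for inhibition, read by trypan blue exclusion, with a stated time of 96 h (on this read-out higher numbers stand for weaker inhibition of growth and lower numbers for stronger inhibition of growth), are
compound 1 `O=C(/C(=C\c1ccc(O)c([N+](=O)[O-])c1)S(=O)(=O)Cc1ccc(Br)cc1)c1ccc(Br)cc1` with 10000 nM
compound 2 `O=C(/C(=C\c1ccc(Br)c([N+](=O)[O-])c1)Sc1ccc(Br)cc1)c1ccc(Br)cc1` with 1000 nM
compound 3 `O=C(/C(=C\c1ccc(O)c([N+](=O)[O-])c1)S(=O)(=O)c1ccc(I)cc1)c1ccc(Br)cc1` with 25000 nM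

Compound 3 (25000 nM) has the highest number of the three. Compound 4 `O=C(/C(=C\c1ccc(O)c([N+](=O)[O-])c1)Sc1ccc(Br)cc1)c1ccc(Br)cc1` differs from it by (4-bromophenyl)sulfanyl in place of (4-iodophenyl)sulfonyl on a double-bonded chain carbon bound to a carbonyl carbon and a double-bonded chain carbon with (4-bromophenyl)sulfanyl in place of (4-iodophenyl)sulfonyl on a double-bonded chain carbon bound to a carbonyl carbon and a double-bonded chain carbon. Among the compounds with values here, the only measured step nearby was modest, a 2.5-fold higher number from compound 1 to compound 3 (0.40 log units; beyond the scatter) and it kept the sulfonyl. Within the data shown here, compound 2 carries the same (4-bromophenyl)sulfanyl group and gives 1000 nM on a different core, so a lower number is expected, though no measured step isolates this change. The expected change in this assay is an 8.3-fold lower number from compound 3 to compound 4 (0.92 log units; beyond the scatter) and it is clearly beyond the scatter. For compound 4 the estimated value is 3000 nM (expected range 800 nM to 12000 nM).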

Compound 4, concentration for 50% growth inhibition: 1000 nM
Beside the measured number, compound 4's estimate is 3.0-fold (0.48 log units) above it; low and high end bracket the measured number.
By their numbers in this assay, from the lowest: compounds 2 and 4 (each within the scatter of the next); then compound 1; then compound 3.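

In this assay, this position proves far more sensitive than the sulfonyl-bearing compounds suggested: a 25-fold lower number from compound 3 to compound 4 (1.40 log units; beyond the scatter), against only a 2.5-fold higher number from compound 1 to compound 3 (0.40 log units; beyond the scatter) on the earlier step. With (4-bromophenyl)sulfanyl in place, hydroxy and bromo on the aromatic carbon cannot be told apart, with no change at the digits printed from compound 2 to compound 4 (within the scatter). Nothing available offers an explanation for the large step.

The compounds shown do not separate the change from sulfonyl to sulfanyl from the change from iodine to bromine. As far as these compounds go, whether a methoxy group or an amine on that aromatic carbon would fit as well as hydroxy and bromo remains open.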